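Adding a chloro group beside the trifluoromethyl pyridine

The source may report more compounds than this note shows. Statements on the series, on what has been measured and on what is new or still open speak of the compounds shown alone.

Measured so far, in a functional assay (Homo sapiens), tested at 1 uM; on this read-out higher numbers stand for a weaker effect at the one concentration tested and lower numbers for a stronger effect:
compound 1 `O=C(CCCc1ccc(C(F)(F)F)cn1)N1CCc2c(Cl)c(O)c(O)c(Cl)c2C1` gives 72%
compound 2 `N#Cc1ccc(CCCC(=O)N2CCc3c(Cl)c(O)c(O)c(Cl)c3C2)nc1` gives 86%
compound 3 `CS(=O)(=O)c1ccc(CCCC(=O)N2CCc3c(Cl)c(O)c(O)c(Cl)c3C2)nc1` gives 99%

Compound 1 shows the lowest number of the three, that is the strongest effect; compound 2 stands a number 14 percentage points higher from compound 1 to compound 2 (beyond the scatter), compound 3 stands a number 27 percentage points higher from compound 1 to compound 3 (beyond the scatter), and between those two the step is a number 13 percentage points higher from compound 2 to compound 3 (beyond the scatter). All three measured steps exchange the trifluoromethyl group itself for another group.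

Compound 4 `O=C(CCCc1ncc(C(F)(F)F)cc1Cl)N1CCc2c(Cl)c(O)c(O)c(Cl)c2C1` keeps the trifluoromethyl group and differs from compound 1 by chloro in place of hydrogen on an aromatic carbon. The new chloro sits ortho to a large group, two atoms from the ring nitrogen and meta to the trifluoromethyl group. Among the measured compounds shown here, none of the measured steps adds a group at this place while leaving the trifluoromethyl group untouched, so no measured step bears directly on this change. With nothing to show a shift, compound 4 is expected to stay close to compound 1, a step of no change at the digits printed from compound 1 to compound 4 (within the scatter) that lies within the usual scatter. The estimate for compound 4 in this assay is 72%, with a range from 55% to 88%.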

Compound 4, a percentage reported as activity, at one concentration (the size of the read-out at that concentration, not a potency): 61%
For compound 4 the middle estimate is 11 percentage points above the measured one; measured number inside the range.
By their numbers in this assay, from the lowest: compound 4; then compound 1; then compound 2; then compound 3.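

In this assay, chloro in place of hydrogen on this aromatic carbon gives a number 11 percentage points lower from compound 1 to compound 4 (beyond the scatter), a shift toward a stronger effect at the one concentration tested. The earlier steps shown here only exchanged the trifluoromethyl group itself, whereas this one keeps that group and shows that a change at a second place on the ring, ortho to a large group and two atoms from the ring nitrogen, can also move the read-out beyond the scatter. Nothing available explains why this step goes the way it does.

A single step cannot tell whether the shift is specific to chloro, and a fluoro, methyl or amine group on the same carbon would address that. As far as these compounds go, it also remains open whether adding chloro at this place would give a similar step in compound 2 or compound 3, which carry cyano and methylsulfonyl instead of trifluoromethyl.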